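Swapping the Amine Tail Across Two Cores

The source may report more compounds than this note shows. Statements on the series, on what has been measured and on what is new or still open speak of the compounds shown alone.

Four compounds share one core and differ at two ends. Compound 1 `COc1ccc(/C=C/c2nc(NCCN(C(C)C)C(C)C)c3ccccc3n2)cc1OC` carries a diisopropylamino tail and a 3,4-dimethoxyphenyl group; in a functional assay on DU-145 cells (Homo sapiens) for cytotoxicity, read by MTT assay, with stated times of 48 h and 4 h (on this read-out lower numbers stand for stronger inhibition and higher numbers for weaker inhibition), compound 1 gives 15000 nM. Compound 2 `COc1ccc(/C=C/c2nc(NCCN3CCCCC3)c3ccccc3n2)cc1OC` differs from compound 1 by piperidin-1-yl in place of diisopropylamino on a saturated chain carbon, two bonds along the chain from a nitrogen on an aromatic ring, and in this assay compound 2 gives 71600 nM, so that a 4.8-fold higher number from compound 1 to compound 2 (0.68 log units; beyond the scatter). Compound 3 `CC(C)N(CCNc1nc(/C=C/c2ccc([N+](=O)[O-])cc2)nc2ccccc12)C(C)C` differs from compound 1 by 4-nitrophenyl in place of 3,4-dimethoxyphenyl on a double-bonded chain carbon bound to a double-bonded chain carbon. For compound 3 this assay reports only a limit, > 100000 nM, which is the limit of > 100000 nM in this assay, at which 1 of the 3 values shown sits. Accordingly an at least 6.6-fold higher number from compound 1 to compound 3 (0.82 log units; beyond the scatter).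

Compound 4 `O=[N+]([O-])c1ccc(/C=C/c2nc(NCCN3CCCCC3)c3ccccc3n2)cc1` is not yet measured. It differs from compound 3 by piperidin-1-yl in place of diisopropylamino on a saturated chain carbon, two bonds along the chain from a nitrogen on an aromatic ring, the same change, at the same place, as that from compound 1 to compound 2. Since compound 3 already sits at the limit, and since the same change weakened inhibition as shown by a 4.8-fold higher number from compound 1 to compound 2 (0.68 log units; beyond the scatter), the expected step that the limit leaves unreadable from compound 3 to compound 4 points the same way. For compound 4 the expected value is 400000 nM, estimated to lie between 100000 nM and 2000000 nM, and most likely this assay would again report only a limit.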

Compound 4, half-maximal inhibitory concentration: > 100000 nM
Compound 4: a limit, no number; the forecaster's own chance of this, stated with the estimate: 90%; the middle value lies beyond the limit too.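

Compound 4 gives > 100000 nM in this assay, which is a limit and not a number. Going by these compounds alone, the step from compound 3 to compound 4 therefore cannot be read, so it remains unknown whether the swap from diisopropylamino to piperidin-1-yl carries over to the core of compound 3, and the only readable new step is an at least 1.3-fold higher number from compound 2 to compound 4 (0.14 log units; that floor lies within the scatter). The change from 3,4-dimethoxyphenyl to 4-nitrophenyl can thus be compared on the two tails only through floors, which shows neither that it carries over unchanged nor that it does not: the same change on two cores in this assay, an at least 6.6-fold higher number (0.82 log units; beyond the scatter) from compound 1 to compound 3 and an at least 1.3-fold higher number (0.14 log units; that floor lies within the scatter) from compound 2 to compound 4; the limit leaves it open whether they differ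

The compounds shown leave open how a dimethylamino or morpholin-4-yl tail, or a longer chain in the tail, would behave on either core. They also leave open whether a group such as 4-methoxyphenyl in place of 4-nitrophenyl would give readable numbers on both sides of the tail swap.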